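Bromo to Methoxy, Repeated on a Second Core

The compounds below may be only part of what the source reports. "The series", "measured", "known", "first", "only" and "open" are said of these compounds alone.

Measured compounds:
Compound 1, `CO[C@@H]1[C@H](N(C)c2ncc(-c3c[nH]c4ccc(Br)cc34)s2)C[C@H]2O[C@]1(C)n1c3ccccc3c3c4c(c5c6cc(Cl)ccc6n2c5c31)C(=O)NC4`, gives 430 nM in a functional assay on MV4-11 cells (Homo sapiens) for antiproliferative activity, read by CellTiter-Glo, with a stated time of 72 h; a higher number here means a weaker inhibitor, a lower number a stronger inhibitor.
Compound 2, `COc1ccc2[nH]cc(-c3cnc(N(C)[C@@H]4C[C@H]5O[C@@](C)([C@@H]4OC)n4c6ccccc6c6c7c(c8c9cc(Cl)ccc9n5c8c64)C(=O)NC7)s3)c2c1`, gives 440 nM in this assay.
Compound 3, `CO[C@@H]1[C@H](N(C)c2ncc(-c3c[nH]c4ccc(Br)cc34)s2)C[C@H]2O[C@]1(C)n1c3ccccc3c3c4c(c5c6cc(Br)ccc6n2c5c31)C(=O)NC4`, gives 390 nM in this assay.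

Three compounds share a large fused core carrying a side arm that ends in an indole. Compound 2 differs from compound 1 only in the indole part: methoxy in place of bromo on an aromatic carbon. That change made a 1.0-fold higher number from compound 1 to compound 2 (0.01 log units; within the scatter), so the two compounds behave alike in this assay. Compound 3 differs from compound 1 in the core itself: bromo in place of chloro on an aromatic carbon. That change made a 1.1-fold lower number from compound 1 to compound 3 (0.04 log units; within the scatter), again a step too small to read as a real difference.

Compound 4, `COc1ccc2[nH]cc(-c3cnc(N(C)[C@@H]4C[C@H]5O[C@@](C)([C@@H]4OC)n4c6ccccc6c6c7c(c8c9cc(Br)ccc9n5c8c64)C(=O)NC7)s3)c2c1`, has not been measured. It differs from compound 3 in the indole part: methoxy in place of bromo on an aromatic carbon. This is the same change already seen between compound 1 and compound 2, placed on a core that differs from theirs in the way described above.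

Because a 1.0-fold higher number from compound 1 to compound 2 (0.01 log units; within the scatter) was flat, the expectation for compound 4 is a step of about a 1.0-fold higher number from compound 3 to compound 4 (0.01 log units; within the scatter). Compound 4 is therefore expected to give roughly 400 nM in this assay, estimated between 200 nM and 800 nM. Among the compounds with values here, this rests on only one earlier example of the change, so the estimate is tentative.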

Compound 4, half-maximal inhibitory concentration: 510 nM
Estimate against measurement, compound 4: 1.3-fold (0.11 log units) below; low and high end bracket the measured number.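

In this assay, putting methoxy in place of bromo on the indole of compound 3 gives a 1.3-fold higher number from compound 3 to compound 4 (0.12 log units; within the scatter), and this step agrees with the earlier one: the same change on two cores in this assay, a 1.0-fold higher number (0.01 log units; within the scatter) from compound 1 to compound 2 and a 1.3-fold higher number (0.12 log units; within the scatter) from compound 3 to compound 4, 1.3-fold (0.11 log units) apart, within the scatter of two such steps. Putting bromo in place of chloro on the core, this time with the methoxy indole in place, gives a 1.2-fold higher number from compound 2 to compound 4 (0.06 log units; within the scatter), and this step also agrees with its earlier counterpart: the same change on two cores in this assay, a 1.1-fold lower number (0.04 log units; within the scatter) from compound 1 to compound 3 and a 1.2-fold higher number (0.06 log units; within the scatter) from compound 2 to compound 4, 1.3-fold (0.11 log units) apart, within the scatter of two such steps. So each change stays flat when carried across this pair of closely related compounds, but a flat step repeated only shows that neither change made a readable difference here, and it does not show how a change with a real effect would carry over, or how either change would behave on a more different core.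

The compounds shown hold only bromo or methoxy on the indole and only chloro or bromo on the core, so it remains open whether an amine, a carboxylic acid or a longer chain such as butoxy at these places would shift the number beyond the scatter. On these data alone, whether these flat steps would also hold in any other assay remains open too.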